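The compounds below may be only part of what the source reports. "The series", "measured", "known", "first", "only" and "open" are said of these compounds alone.

Three compounds have been measured in a functional assay on HT-29 cells (Homo sapiens) for cytotoxicity, read by MTT assay, with a stated time of 3 days; a lower number here means a stronger inhibitor, a higher number a weaker inhibitor:

Compound 1, `COc1ccccc1-c1ccccc1O`, gives 2.7 ug/mL.
Compound 2, `Nc1ccccc1-c1ccccc1O`, gives 44 ug/mL.
Compound 3, `COc1ccc(-c2cccc(O)c2)cc1`, gives 72 ug/mL.

Compounds 1 and 2 share a core and differ in one place, (amino in place of methoxy on an aromatic carbon). That single change gave a 16-fold higher number from compound 1 to compound 2 (1.21 log units; beyond the scatter). Compound 3 has the same atoms as compound 1 joined differently; the difference between the two cores is not broken down here. Its number lies close to that of compound 2, within the usual scatter, while the gap to compound 1 is a wide one.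

Compound 4, `Nc1ccc(-c2cccc(O)c2)cc1`, is not yet measured. It relates to compound 3 as compound 2 relates to compound 1: amino in place of methoxy on an aromatic carbon. The place differs, though: in compound 2 the amino sits ortho to a group of 7 heavy atoms, in compound 4 para to it, so this is the same kind of change, not the same change. Among the measured compounds shown here, only one example of it is known, and it made the number much higher, so a weaker inhibitor is expected; the step is estimated as a 2.1-fold higher number from compound 3 to compound 4 (0.32 log units; beyond the scatter), set beside a 16-fold higher number from compound 1 to compound 2 (1.21 log units; beyond the scatter) but more cautious, since compound 3 already gives 72 ug/mL and the placement is not the same. Compound 4 is expected to give about 150 ug/mL, between 50 ug/mL and 500 ug/mL.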

Compound 4, half-maximal inhibitory concentration: 49.3 ug/mL
For compound 4 the middle estimate is 3.0-fold (0.48 log units) above the measured one; the whole stated range lies above it.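

In this assay, putting amino in place of methoxy gave a 1.5-fold lower number from compound 3 to compound 4 (0.16 log units; within the scatter), so on this core the swap has no effect that can be told apart from the ordinary spread of repeated measurements. The same swap on the core of compound 1 gave a large step, so its outcome does not carry over from one core to the other, and the two steps differ by more than their scatter: the same change on two cores in this assay, a 16-fold higher number (1.21 log units; beyond the scatter) from compound 1 to compound 2 and a 1.5-fold lower number (0.16 log units; within the scatter) from compound 3 to compound 4, 24-fold (1.38 log units) apart, beyond the scatter of two such steps. This shows that the result of the swap depends on the core it is made on, but it does not show which difference between the two cores matters, and two examples cannot set a general rule.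

The compounds shown leave open how other groups would behave in place of the methoxy, such as a fluorine atom, an ethoxy group or a carboxylic acid. They also leave open what the same swap from methoxy to amino would do on a third core.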